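The compounds below may be only part of what the source reports. "The series", "measured", "known", "first", "only" and "open" are said of these compounds alone.

Measured so far:
compound 1, `O=C(c1cccnc1)c1ccccc1O`, 31000 nM
compound 2, `O=C(c1cccnc1)c1ccc(Br)cc1O`, 85000 nM
compound 3, `O=C(c1cccnc1)c1cccc(Cl)c1O`, 28000 nM

The read-out throughout is a functional assay on Hep cells (Homo sapiens) for cytotoxicity, read by sulforhodamine B assay, with a stated time of 48 h; on this read-out lower numbers stand for stronger inhibition and higher numbers for weaker inhibition. Compound 1 stands second highest of the three numbers; its nearest neighbour is compound 3, and the two differ only within the scatter, while compound 2 lies furthest from it with a number beyond the scatter.

The unmeasured compound 4 is `O=C(c1cccnc1)c1cc(Cl)ccc1O`. Relative to compound 1 the change is chloro in place of hydrogen on an aromatic carbon, on an aromatic carbon of a six-membered aromatic ring of carbon only, meta to a group of 8 heavy atoms and para to a hydroxy group.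

For the measured compounds named here, two measured steps bear on this. Bromo in place of hydrogen on an aromatic carbon gave a 2.7-fold higher number from compound 1 to compound 2 (0.44 log units; beyond the scatter). A chloro group entering where a hydrogen leaves gave a 1.1-fold lower number from compound 1 to compound 3 (0.04 log units; within the scatter). Both are halogen for hydrogen on the same ring, but at carbons other than the one changed here, so the evidence points to a small step, if any, for compound 4. Compound 4 is therefore expected to come out near compound 1, with the step of a 1.2-fold higher number from compound 1 to compound 4 (0.06 log units; within the scatter), and its estimated value is 36000 nM, within a range of 15000 nM to 85000 nM.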

Compound 4, half-maximal inhibitory concentration: 27000 nM
Estimate against measurement, compound 4: 1.3-fold (0.12 log units) above; the range from low to high includes it.
By their numbers in this assay, from the lowest: compounds 4, 3 and 1 (each within the scatter of the next); then compound 2.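

In this assay, chloro in place of hydrogen on the aromatic carbon para to a hydroxy group and meta to a group of 8 heavy atoms gives a 1.1-fold lower number from compound 1 to compound 4 (0.06 log units; within the scatter), so this carbon accepts chloro without a shift beyond the scatter. Together with a 1.1-fold lower number from compound 1 to compound 3 (0.04 log units; within the scatter), chloro now stands at two different carbons of this ring with both steps within the scatter, while the only step beyond it among those shown is the bromo one, a 2.7-fold higher number from compound 1 to compound 2 (0.44 log units; beyond the scatter). No measurement at hand bears on the reason for this result.

Open is whether the bromo step follows from the halogen or from its carbon, since bromo and chloro sit at different carbons in the compounds shown. Also open, from the compounds shown here alone, is how an amine, a carboxylic acid or a longer chain would read out at this carbon.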